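A few compounds are considered here, and "the series" means these few. Any claim that something is new, unique, unknown or untested is made for them only; others in the source may bear on it.

Measured compounds:
compound 1, `CCCCC[Se]c1nc(NCc2ccccc2)c2ccccc2n1`, gives > 100000 nM, a limit of the assay
compound 2, `CCCCCSc1nc(NCc2ccc([Se]C)cc2)c2ccccc2n1`, gives > 100000 nM, a limit of the assay
compound 3, `CSc1nc(NCc2ccccc2)c2ccccc2n1`, gives > 100000 nM, a limit of the assay

All three were tested in an ADME assay on 184B5 cells (Homo sapiens) for cytotoxicity, read by MTT assay, with a stated time of 72 h; on this read-out higher numbers stand for weaker inhibition of growth and lower numbers for stronger inhibition of growth. For compound 3 the reported value is a limit of the assay, not a number. The same holds for compound 1 and for compound 2, so compound 3 stands at the limit together with both of the others, as shown by the limit of > 100000 nM in this assay, at which 3 of the 3 values shown sit. The step that the two limits leave unreadable from compound 1 to compound 3 is therefore not readable, since both of its ends are limits.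

Compound 4, `CSc1nc(NCc2ccc([Se]C)cc2)c2ccccc2n1`, differs from compound 3 by a group of 2 heavy atoms (1 carbon, 1 selenium; no ring) in place of a hydrogen atom, on an aromatic carbon. Going by the values given here, no measured step bears directly on this change. Compound 2 carries the same group on the same ring and sits at the limit like the others, so no shift beyond the scatter is expected from it. Compound 4 is therefore expected to remain at the limit, with an estimated step that the limit leaves unreadable from compound 3 to compound 4 and an estimated value of 150000 nM, in the range from 50000 nM to 500000 nM.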

Compound 4, concentration for total growth inhibition: > 100000 nM
Compound 4: no number, only a limit (the forecaster's own chance of this, stated with the estimate: 85%); the middle value lies beyond the limit too.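

Compound 4 gives only a limit of the assay, as do compound 2 and compound 3, so neither step to compound 4 can be read: the limit of > 100000 nM in this assay, at which 4 of the 4 values shown sit. The compounds shown leave open whether either change shifts growth inhibition in this assay at all.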